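A few compounds are considered here, and "the series" means these few. Any claim that something is new, unique, unknown or untested is made for them only; others in the source may bear on it.

Compound 1 `COc1ccc(C(=O)Nc2ccc(CCS(=O)(=O)/C=C/c3ccc(OC(C)=O)c(OC(C)=O)c3)cc2)cc1` is a benzamide whose amide carries a methoxy group. In an ADME assay on TZM cells (Homo sapiens) for cytotoxicity, read by CCK-8 assay, with a stated time of 2 days (a lower number here means that less compound is tolerated, a higher number that more compound is tolerated), compound 1 gives 858000 nM. Compound 2 `CC(=O)Oc1ccc(/C=C/S(=O)(=O)CCc2ccc(NC(=O)c3ccc(F)cc3)cc2)cc1OC(C)=O` differs from it in one place: fluoro in place of methoxy on an aromatic carbon. The step from compound 1 to compound 2 in this assay is a 5.3-fold lower number from compound 1 to compound 2 (0.72 log units; beyond the scatter), so less of compound 2 is tolerated.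

Compound 3 `COc1ccc(C(=O)Nc2ccc(CC[S+]([O-])/C=C/c3ccc(O)c(O)c3)cc2)cc1` carries the same methoxy benzamide on a different core; the difference between the two cores is not broken down here. In this assay compound 3 gives "not determined" (no result reported), so no number is available for it. Compound 4 `O=C(Nc1ccc(CC[S+]([O-])/C=C/c2ccc(O)c(O)c2)cc1)c1ccc(F)cc1` stands to compound 3 exactly as compound 2 stands to compound 1: fluoro in place of methoxy on an aromatic carbon, the place being the same in both pairs, so it is the same change.

Since compound 3 has no number, the step to compound 4 cannot be computed, and the expectation for compound 4 rests on compound 2, whose value is 162000 nM, with the shared fluoro group. On that basis compound 4 is expected to fall near 150000 nM, within a range from 40000 nM to 600000 nM, the width reflecting that the core change is unmeasured here.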

Compound 4, half-maximal cytotoxic concentration: 127000 nM
Beside the measured number, compound 4's estimate is 1.2-fold (0.07 log units) above it, and the stated range covers the measured number.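

For the compounds shown here, compound 3 has no number to set against compound 4, so no step between the two can be read in this assay. The compounds shown leave open whether fluoro in place of methoxy changes the tolerated concentration on this core as it does on the core of compound 1. No supporting data bear on compound 4's result.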